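This account rests on a few compounds, and the source may have more. Where it says the series, first, only, none or still open, it means among the compounds named here.

Compound 1 `FC(F)(F)c1ccc(CN2CCN(Cc3cc(-c4ccc(OCc5cccc(Cl)c5)cc4)on3)CC2)cc1` is the starting point: in a functional assay on MCF7 cells (Homo sapiens) for antiproliferative activity, read by sulforhodamine B assay, with a stated time of 72 h (on this read-out lower numbers stand for stronger inhibition and higher numbers for weaker inhibition), compound 1 gives 1400 nM. Compound 2 `N#Cc1ccccc1COc1ccc(-c2cc(CN3CCN(Cc4ccc(C(F)(F)F)cc4)CC3)no2)cc1` carries a 2-cyanophenyl in place of the 3-chlorophenyl on a saturated chain carbon bound to an oxygen on an aromatic ring, and in this assay compound 2 gives 4000 nM, so that a 2.9-fold higher number from compound 1 to compound 2 (0.46 log units; beyond the scatter).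

Compound 3 `N#Cc1cccc(COc2ccc(-c3cc(CN4CCN(c5ccc(C(F)(F)F)cn5)CC4)no3)cc2)c1` keeps a nitrile-bearing phenyl at that position and puts a 5-(trifluoromethyl)pyridin-2-yl on the amine nitrogen of the six-membered non-aromatic ring with two nitrogens; in this assay compound 3 gives 1400 nM. Its number is level with that of compound 1 at the digits shown, and the two together sit at the lowest level of the three, while compound 2 is the one furthest from compound 3, showing the higher number.

Compound 4 `N#Cc1cccc(COc2ccc(-c3cc(CN4CCN(CC5CCCO5)CC4)no3)cc2)c1` differs from compound 3 in one place: (oxolan-2-yl)methyl in place of 5-(trifluoromethyl)pyridin-2-yl on an amine nitrogen in a ring. Going by the values given here, the single measured step, from compound 1 to compound 2, concerns the group on the saturated chain carbon, not the amine nitrogen, so no comparison here speaks directly to this change. Without such guidance, compound 4 is expected to give roughly 3000 nM, with a range from 1000 nM to 10000 nM, meaning an expected step of a 2.1-fold higher number from compound 3 to compound 4 (0.33 log units; beyond the scatter).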

Compound 4, half-maximal inhibitory concentration: 8400 nM
Beside the measured number, compound 4's estimate is 2.8-fold (0.45 log units) below it; measured number inside the range.
By their numbers in this assay, from the lowest: compounds 1 and 3 (each within the scatter of the next); then compound 2; then compound 4.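

Going by these compounds alone, the earlier single-place step changed only the group on the saturated chain carbon bound to an oxygen, so this pair gives the first direct reading at the amine nitrogen of the six-membered ring: in this assay, there is a 6.0-fold higher number from compound 3 to compound 4 (0.78 log units; beyond the scatter) with the rest of the molecule held constant. This position is therefore not indifferent to its substituent, since replacing the aromatic 5-(trifluoromethyl)pyridin-2-yl with the non-aromatic (oxolan-2-yl)methyl, which has fewer heavy atoms, goes with weaker inhibition. No supporting measurement explains why the number rises, and this single pair cannot separate the several differences between the two groups.

Going by these compounds, it remains open whether the shift follows the aromatic ring, the trifluoromethyl group, or the chain carbon that joins the oxolane ring to the amine nitrogen. An unsubstituted phenyl, a pyridin-2-yl without trifluoromethyl, or a cyclopentylmethyl on that nitrogen would each test one of these differences on its own, and so would show which of them goes with the change.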